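Swapping the aryl group on the ring nitrogen

This account rests on a few compounds, and the source may have more. Where it says the series, first, only, none or still open, it means among the compounds named here.

Compound 1 `COc1ccc(Cl)cc1N1CCN(C(=O)c2oc(C)nc2-c2ccccc2F)CC1`: 153 nM
Compound 2 `Cc1ccc(C)c(N2CCN(C(=O)c3oc(C)nc3-c3ccccc3F)CC2)c1`: 319 nM

For the measured compounds named here, in a functional assay on HL-60 cells (Homo sapiens) for inhibition, read by MTT assay, with a stated time of 72 h (on this read-out higher numbers stand for weaker inhibition and lower numbers for stronger inhibition), compound 2 stands at the higher of the two numbers so far, with 319 nM, while compound 1 gives 153 nM. Compound 3 `Cc1nc(-c2ccccc2F)c(C(=O)N2CCN(c3cc(F)cc(F)c3)CC2)o1` has yet to be measured. It carries 3,5-difluorophenyl in place of 2,5-dimethylphenyl on an amine nitrogen in a ring. Going by the values given here, only one measured step bears on this change, also made on that amine nitrogen: a 2.1-fold higher number from compound 1 to compound 2 (0.32 log units; beyond the scatter), a modest change beyond the scatter. That single step does not show which way the new group will move the number. A step of similar or smaller size is therefore expected in this assay, with no settled direction, and it may not exceed the scatter. The expected change is a 1.1-fold higher number from compound 2 to compound 3 (0.04 log units; within the scatter). Compound 3 is estimated at 350 nM, with an expected range from 120 nM to 1000 nM.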

Compound 3, half-maximal inhibitory concentration: 186 nM
Estimate against measurement, compound 3: 1.9-fold (0.27 log units) above; the range from low to high includes it.
By their numbers in this assay, from the lowest: compounds 1, 3 and 2 (each within the scatter of the next, the first and the last beyond it).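

In this assay, placing 3,5-difluorophenyl on the amine nitrogen in a ring in place of 2,5-dimethylphenyl gives a 1.7-fold lower number from compound 2 to compound 3 (0.23 log units; within the scatter), and placing it there in place of 5-chloro-2-methoxyphenyl gives a 1.2-fold higher number from compound 1 to compound 3 (0.08 log units; within the scatter). A phenyl ring carrying only fluorine thus lies within the scatter of both earlier groups, even though those two are themselves separated by a 2.1-fold higher number from compound 1 to compound 2 (0.32 log units; beyond the scatter). Nothing available explains these numbers.

From the compounds shown here alone, whether a plain phenyl or a single fluorine on the phenyl would stay in the same range remains open. Going by these compounds, it is equally open what a pyridine ring, a benzyl group or a phenyl bearing a carboxylic acid would give on this nitrogen.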